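A few compounds are considered here, and "the series" means these few. Any claim that something is new, unique, unknown or untested is made for them only; others in the source may bear on it.

Of the compounds shown here, two sharing a common core have so far been measured in a functional assay on NCI-H1975 cells (Homo sapiens) for inhibition, read by MTT assay, with a stated time of 72 h; a higher number here means a weaker inhibitor, a lower number a stronger inhibitor. Compound 1 `O=C(CSc1nc(Nc2ccccc2)c2ccccc2n1)Nc1ccc(Cl)cc1` gives 8040 nM in this assay. Compound 2 `C=CC(=O)Nc1cccc(NC(=O)CSc2nc(Nc3cccc([N+](=O)[O-])c3)c3ccccc3n2)c1` gives 22600 nM in this assay, the highest of the two numbers; its nearest neighbour is compound 1, whose number is lower by a gap beyond the scatter. Among the compounds with values here, the two differ in more than one place, so no single step connects them. Compound 3 `C=CC(=O)Nc1cccc(NC(=O)CSc2nc(Nc3ccc(Cl)cc3Cl)c3ccccc3n2)c1` has not yet been measured. It differs from compound 2 in one place: 2,4-dichlorophenyl in place of 3-nitrophenyl on a nitrogen on an aromatic ring. Nothing measured here shows how this exchange acts in this assay, so one expects the step from compound 2 to compound 3 to be small, probably within the scatter, in either direction. Compound 3 is therefore expected to give about 16000 nM in this assay, with a range from 5000 nM to 50000 nM. This estimate means an expected step of a 1.4-fold lower number from compound 2 to compound 3 (0.15 log units; within the scatter).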

Compound 3, half-maximal inhibitory concentration: 5990 nM
Compound 3: middle estimate off by 2.7-fold (0.43 log units), on the high side, within the range that was stated.
By their numbers in this assay, from the lowest: compounds 3 and 1 (each within the scatter of the next); then compound 2.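

With the rest of the structure unchanged, replacing 3-nitrophenyl with 2,4-dichlorophenyl on a nitrogen on an aromatic ring gives a 3.8-fold lower number from compound 2 to compound 3 (0.58 log units; beyond the scatter) in this assay. This shows that the group at this position can shift the number beyond the scatter, in the direction of a stronger inhibitor, which the earlier pair of compounds could not show because they differ in more than one place. The data offered here give no explanation for this step.

The exchange removes the nitro group and brings in both chlorines in a single step, so the share of each in the change remains unresolved. As far as these compounds go, it also remains open how this position would respond to an amine or a methoxy group on the phenyl ring.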